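The source may report more compounds than this note shows. Statements on the series, on what has been measured and on what is new or still open speak of the compounds shown alone.

Of the compounds shown here, two of a shared core have been measured in a functional assay on WM 266-4 cells (Homo sapiens) for inhibition, read by MTT assay, with a stated time of 24 h; on this read-out lower numbers stand for stronger inhibition of growth and higher numbers for weaker inhibition of growth. Compound 1, with the structure `COc1ccc(C2=NN(C(=O)c3ccc4c(c3)OCCO4)C(c3ccc(F)cc3)C2)cc1`, gives 3780 nM in this assay. Compound 2, with the structure `O=C(c1ccc2c(c1)OCCO2)N1N=C(c2ccccc2)CC1c1ccccc1F`, gives 2500 nM. The two numbers sit close together: the gap between compound 2 and compound 1 is within the usual scatter of repeated measurements, so compound 2 cannot be called either stronger or weaker than compound 1; it simply stands beside it.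

Compound 3, with the structure `COc1ccc(C2=NN(C(=O)c3ccc4c(c3)OCCO4)C(c3ccccc3F)C2)cc1`, has not yet been measured. It differs from compound 2 in one place: methoxy in place of hydrogen on an aromatic carbon. Read one bond further out, the change is phenyl to 4-methoxyphenyl, on an aromatic carbon para to a large group.

Within the data shown here, no measured pair in this set shows this exact change on its own, so there is no directly comparable step to lean on. Because compound 1 already carries a methoxy group and gives 3780 nM, close to compound 2, the change from compound 2 to compound 3 is expected to produce no shift beyond the scatter, giving a 1.2-fold higher number from compound 2 to compound 3 (0.08 log units; within the scatter). The estimate for compound 3 in this assay is 3000 nM, with a likely range from 1500 nM to 6500 nM.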

Compound 3, concentration for 50% growth inhibition: 3470 nM
For compound 3 the middle estimate is 1.2-fold (0.06 log units) below the measured one, within the range that was stated.
By their numbers in this assay, from the lowest: compounds 2, 3 and 1 (each within the scatter of the next).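

In this assay, among these compounds, methoxy in place of hydrogen on the aromatic carbon para to a large group gives a 1.4-fold higher number from compound 2 to compound 3 (0.14 log units; within the scatter), the first reading of this change on its own, and with the 2-fluorophenyl group held fixed it leaves no shift that can be told from the scatter. The new compound also isolates a second change: with the 4-methoxyphenyl group held fixed, 2-fluorophenyl in place of 4-fluorophenyl on a saturated ring carbon gives a 1.1-fold lower number from compound 1 to compound 3 (0.04 log units; within the scatter), so this swap likewise stays within the scatter in this set. Nothing available here accounts for either result.

Going by these compounds, these two steps cover only hydrogen and methoxy at the aromatic position, so it remains open whether a different kind of group there, such as an amine, a carboxylic acid or a longer chain like butoxy, would move the number beyond the scatter. On these data alone, it is equally open whether a group other than fluorine on the phenyl ring at the saturated carbon, such as chlorine or hydroxyl, would do so.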